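Trading a 2-fluorophenyl for a 4-(dimethylsulfamoyl)phenyl

The compounds below may be only part of what the source reports. "The series", "measured", "known", "first", "only" and "open" are said of these compounds alone.

Compound 3 `O=C(O)C[C@H](O)C[C@H](O)CCn1c(-c2ccc(F)cc2)nc(C(=O)NCc2ccccc2F)c1C1CC1` gives 27200 nM in a functional assay on L6 cells (Rattus norvegicus) for inhibition, read by scintillation counting, with a stated time of 3 h (on this read-out higher numbers stand for weaker inhibition and lower numbers for stronger inhibition), the highest of the three numbers recorded. Compound 1 `COc1ccc(CNC(=O)c2nc(-c3ccc(F)cc3)n(CC[C@@H](O)C[C@@H](O)CC(=O)O)c2C2CC2)cc1` gives 6400 nM and compound 2 `CC(C)c1c(C(=O)NCc2ccccc2)nc(-c2ccc(F)cc2)n1CC[C@@H](O)C[C@@H](O)CC(=O)O` gives 3030 nM. Among the compounds with values here, only one measured step bears on the change at hand: a 4.3-fold higher number from compound 1 to compound 3 (0.63 log units; beyond the scatter), a modest step. Compound 4 `CN(C)S(=O)(=O)c1ccc(CNC(=O)c2nc(-c3ccc(F)cc3)n(CC[C@@H](O)C[C@@H](O)CC(=O)O)c2C2CC2)cc1` differs from compound 3 in that (4-(dimethylsulfamoyl)phenyl in place of 2-fluorophenyl on a saturated chain carbon bound to an amide-type nitrogen). Since compound 4, like compound 1, carries a 4-substituted phenyl on the saturated chain carbon bound to an amide-type nitrogen, the step is expected to run opposite to a 4.3-fold higher number from compound 1 to compound 3 (0.63 log units; beyond the scatter), towards a lower number beyond the scatter. Compound 4 is therefore estimated at 5000 nM, with a range from 1500 nM to 16000 nM. That estimate means a step of a 5.4-fold lower number from compound 3 to compound 4 (0.74 log units; beyond the scatter).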

Compound 4, half-maximal inhibitory concentration: > 100000 nM
Compound 4: a limit, no number (the forecaster's own chance of this, stated with the estimate: 5%); at least 20-fold (1.30 log units) between middle value and limit.
By their numbers in this assay, from the lowest: compound 2; then compound 1; then compound 3. At a limit, above all of these: compound 4.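

Compound 4 reads as a limit and not as a number: the limit of > 100000 nM in this assay, at which 1 of the 4 values shown sits.

A 4-substituted phenyl on the saturated chain carbon bound to an amide-type nitrogen therefore does not by itself bring a lower number, since the exchange gives an at least 3.6-fold higher number from compound 3 to compound 4 (0.56 log units; beyond the scatter). What sits on the aromatic carbon matters at least as much, with dimethylsulfamoyl in place of methoxy giving an at least 15-fold higher number from compound 1 to compound 4 (1.19 log units; beyond the scatter).

Going by these compounds, how an amine or a carboxylic acid in place of dimethylsulfamoyl on that aromatic carbon would read remains open. So does the true value of compound 4.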